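A few compounds are considered here, and "the series" means these few. Any claim that something is new, unique, unknown or untested is made for them only; others in the source may bear on it.

Measured in an ADME assay on HEK293 cells (Homo sapiens) for inhibition, read by MTT assay, with stated times of 18 h and 4 h; on this read-out higher numbers stand for weaker inhibition and lower numbers for stronger inhibition:
- compound 1 `CCCCCCCCOP(=O)(O)OCCSC(=S)N1CCCCC1`: 69000 nM
- compound 2 `CCCCCCCCOP(=O)(O)OCCSC(=S)N1CCN(C)CC1`: 86000 nM
- compound 3 `CCCCCCCCOP(=O)(O)OCCSC(=S)N1CCCCCC1`: > 100000 nM

Compound 1 gives 69000 nM, and compound 2 gives 86000 nM. These two values lie within the scatter of each other, so neither stands apart. Compound 3 gives > 100000 nM, which is a limit of the assay and not a number.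

Next in the series is compound 4 `CCCCCCCCCCOP(=O)(O)OCCSC(=S)N1CCCCC1`, which differs from compound 1 at the chain: ethyl in place of hydrogen on a saturated chain carbon, eight bonds along the chain from an oxygen on an unsaturated carbon. In words, ethyl replaces hydrogen on a saturated chain carbon, eight bonds along the chain from an oxygen on an unsaturated carbon.

The measured steps all exchange the group on the thiocarbonyl carbon: a 1.2-fold higher number from compound 1 to compound 2 (0.10 log units; within the scatter), an at least 1.4-fold higher number from compound 1 to compound 3 (0.16 log units; that floor lies within the scatter) and an at least 1.1-fold higher number from compound 2 to compound 3 (0.06 log units; that floor lies within the scatter). None of them alters the chain, so they bear on this change only indirectly. They show that this assay has so far moved little across the series, and the last two are floors only. No step beyond the scatter is therefore expected, with a slight lean towards a lower number, though the data do not test this place and the range stays wide. The expected step is a 1.5-fold lower number from compound 1 to compound 4 (0.19 log units; within the scatter). For compound 4 the estimated value is 45000 nM, with an expected range from 15000 nM to 100000 nM.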

Compound 4, half-maximal inhibitory concentration: 70700 nM
The estimate for compound 4 lay 1.6-fold (0.20 log units) below the measured number, and the stated range covers the measured number.
By their numbers in this assay, from the lowest: compounds 1, 4 and 2 (each within the scatter of the next). At a limit, above all of these: compound 3.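

In this assay, ethyl in place of hydrogen on a saturated chain carbon, eight bonds along the chain from an oxygen on an unsaturated carbon, gives a 1.0-fold higher number from compound 1 to compound 4 (0.01 log units; within the scatter). Going by these compounds alone, this is the first reading at the chain rather than at the group on the thiocarbonyl carbon, and at this place the ethyl leaves the read-out inside the scatter. Compound 1, compound 4 and compound 2 now form a run of values, each within the scatter of the next, so neither the change at the chain nor the change on the thiocarbonyl carbon has yet separated any two measured numbers in the series.

From the compounds shown here alone, whether a longer chain, or an amine or a carboxylic acid on the chain at this place, would give a step beyond the scatter stays open, as does the effect of the same ethyl on the azepan-1-yl and 4-methylpiperazin-1-yl compounds. The upper end of the read-out also stays unresolved, with compound 3 given only as a limit and not a number: the limit of > 100000 nM in this assay, at which 1 of the 4 values shown sits.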